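Methyl for isopropyl on the fused core of compound 2

The compounds below may be only part of what the source reports. "The series", "measured", "known", "first", "only" and "open" are said of these compounds alone.

Compound 1 `CCCc1nc(C)c2c(C)nn(CCC)c(=O)n12`: > 48000 nM, a limit of the assay
Compound 2 `CSc1nncc2c(C(C)C)ncn12`: > 48000 nM, a limit of the assay
Compound 3 `CC(C)c1ncn2c(O)nncc12`: > 48000 nM, a limit of the assay

In a functional assay for inhibition, with Homo sapiens as the target (on this read-out lower numbers stand for stronger inhibition and higher numbers for weaker inhibition), compound 2 gives no number, only a limit, > 48000 nM. Compound 1 likewise stands at a limit, > 48000 nM. Compound 3 also stands at a limit, > 48000 nM. Within the data shown here, the single step between measured compounds, a step that the two limits leave unreadable from compound 2 to compound 3, cannot be read because of the limit of > 48000 nM in this assay, at which 3 of the 3 values shown sit. Compound 4 `CSc1nncc2c(C)ncn12` differs from compound 2 by methyl in place of isopropyl on an aromatic carbon. Among the measured compounds shown here, no measured step bears on this change, and no value gives a readable size in either direction. The step expected is a step that the limit leaves unreadable from compound 2 to compound 4, nothing beyond the scatter. Compound 4 is therefore expected at about 80000 nM, within a range from 30000 nM to 300000 nM, and most likely reported again only as a limit.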

Compound 4, half-maximal inhibitory concentration: > 48000 nM
Compound 4: only a limit was reported; the forecaster's own chance of this, stated with the estimate: 85%; the middle value lies beyond the limit too.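

No step can be read from compound 2 to compound 4, because both stand at a limit: the limit of > 48000 nM in this assay, at which 4 of the 4 values shown sit.

The compounds shown leave open whether methyl in place of isopropyl changes inhibition at all, and what structure would give a readable value.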